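The compounds below may be only part of what the source reports. "The series", "measured", "known", "first", "only" and "open" are said of these compounds alone.

In an ADME assay on HEK293 cells (Homo sapiens) for cytotoxicity, read by MTT assay, with a stated time of 48 h (a lower number here means a stronger inhibitor, a higher number a weaker inhibitor), the measured compounds are:

Compound 1 `Cc1cc(NC(=O)c2ccc(C#N)cc2)ccc1NS(C)(=O)=O`: 43500 nM
Compound 2 `Cc1cc(NC(=O)c2cccc(C(F)(F)F)c2)ccc1NS(C)(=O)=O`: 194000 nM
Compound 3 `COc1cc(NC(=O)c2ccc(C#N)cc2)ccc1NS(C)(=O)=O`: > 250000 nM, which is a limit of the assay rather than a number.

The difference between the cores of compound 1 and compound 2 is not broken down here. From compound 1 to compound 3 the change is methoxy in place of methyl on an aromatic carbon, and it gave an at least 5.7-fold higher number from compound 1 to compound 3 (0.75 log units; beyond the scatter), a size that rests on (the limit of > 250000 nM in this assay, at which 1 of the 3 values shown sits).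

Compound 4 `COc1cc(NC(=O)c2cccc(C(F)(F)F)c2)ccc1NS(C)(=O)=O` differs from compound 2 by the same change, (methoxy in place of methyl on an aromatic carbon). Given compound 1 and compound 3 with an at least 5.7-fold higher number from compound 1 to compound 3 (0.75 log units; beyond the scatter), a step of about a 3.1-fold higher number from compound 2 to compound 4 (0.49 log units; beyond the scatter) is expected in this assay. Compound 4 is therefore estimated at 600000 nM, probably between 200000 nM and 2000000 nM, and may well be reported only as a limit.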

Compound 4, half-maximal inhibitory concentration: > 250000 nM
Compound 4 was reported as a limit; the forecaster's own chance of this, stated with the estimate: 80%; the middle value is on the limit's open side.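

In this assay compound 4 gives > 250000 nM, which is a limit of the assay and not a number. On this core, methoxy in place of methyl gives an at least 1.2-fold higher number from compound 2 to compound 4 (0.11 log units; that floor lies within the scatter), so the step shown does not by itself establish a real rise on this core, though a larger one remains possible. The change therefore cannot be said either to carry over with the same size or to differ between the two cores: the same change on two cores in this assay, an at least 5.7-fold higher number (0.75 log units; beyond the scatter) from compound 1 to compound 3 and an at least 1.2-fold higher number (0.11 log units; that floor lies within the scatter) from compound 2 to compound 4; the limit leaves it open whether they differ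

On these data alone, the true positions of compound 3 and compound 4 stay open, as both rest on the same limit: the limit of > 250000 nM in this assay, at which 2 of the 4 values shown sit. Also open is how an amine, a carboxylic acid or a longer chain such as ethoxy would behave in place of methyl on either core.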